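The source may report more compounds than this note shows. Statements on the series, on what has been measured and on what is new or still open speak of the compounds shown alone.

Of the compounds shown here, three of one shared core have been measured in a functional assay on the whole organism (strain L.) for inhibition, with Echinochloa crus-galli as the target, with a stated time of 72 h, tested at 10 mg/L; a lower number here means less inhibition of growth, a higher number more inhibition of growth at the concentration tested. Compound 1 `COc1cc(Cl)nc(NC(=S)NC(=O)c2c(-c3ccc(Cl)cc3Cl)noc2C)n1` gives 18.5%, compound 2 `COc1cc(C)nc(NC(=S)NC(=O)c2c(-c3ccc(Cl)cc3Cl)noc2C)n1` gives 12.3%, and compound 3 `COc1cc(C)nc2n/c(=N/C(=O)c3c(-c4ccc(Cl)cc4Cl)noc3C)sn12` gives 30.9%. Compound 2 shows the lowest of the three numbers, but its gap to compound 1 lies within the usual scatter of the assay, so the two cannot be told apart; only compound 3 sits beyond the scatter above it.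

Going by the values given here, the single step between measured compounds that differs in one place is a number 6.2 percentage points lower from compound 1 to compound 2 (within the scatter), a methyl in place of chloro on an aromatic carbon of the same ring that is changed next.

Compound 4 `CSc1cc(C)nc(NC(=S)NC(=O)c2c(-c3ccc(Cl)cc3Cl)noc2C)n1` differs from compound 2 by methylsulfanyl in place of methoxy on an aromatic carbon. Among the compounds with values here, no measured pair swaps methoxy for methylsulfanyl, so nothing here speaks directly to this exchange. Within the data shown here, the only change on that ring that has been measured, from compound 1 to compound 2, stayed within the scatter, and the exchange in compound 4 is of a similar small size, a two-heavy-atom group for another two-heavy-atom group. A step of a number 1.7 percentage points higher from compound 2 to compound 4 (within the scatter) is therefore expected, meaning no shift beyond the scatter. Compound 4 is estimated at 14%, between 4% and 28%.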

Compound 4, percent growth inhibition at one concentration: 27.4%
Beside the measured number, compound 4's estimate is 13.4 percentage points below it, within the range that was stated.
By their numbers in this assay, from the lowest: compounds 2, 1, 4 and 3 (each within the scatter of the next, the first and the last beyond it).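

In this assay, going by these compounds alone, the change of methoxy to methylsulfanyl gives a number 15.1 percentage points higher from compound 2 to compound 4 (beyond the scatter), whereas the only earlier step on this ring, a number 6.2 percentage points lower from compound 1 to compound 2 (within the scatter), did not clear the scatter. This shows that the position next to the ring nitrogen does respond to substitution, even when sulfur simply takes the place of oxygen and the heavy-atom and hydrogen-bond counts stay the same. The picture is less sharp against the chloro compound: the change from 4-chloro-6-methoxypyrimidin-2-yl to 4-methyl-6-(methylsulfanyl)pyrimidin-2-yl gives a number 8.9 percentage points higher from compound 1 to compound 4 (within the scatter), so the methylsulfanyl compound cannot be told apart from compound 1.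

No measurement here explains why the exchange of oxygen for sulfur moves the number. Still open, from the compounds shown here alone, is whether a longer chain such as ethylsulfanyl, or an amine such as dimethylamino, at this position would move the number further, and whether methylsulfanyl would give a similar step with chloro in place of the methyl group.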